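Fluoro in place of hydrogen on two hydroxamic acid scaffolds

A few compounds are considered here, and "the series" means these few. Any claim that something is new, unique, unknown or untested is made for them only; others in the source may bear on it.

Measured so far:
compound 1 `O=C(NO)c1cccc(OCc2ccc(-c3noc(-c4ccccc4)n3)cc2)c1`: > 100000 nM, a limit of the assay rather than a number
compound 2 `O=C(NO)c1cccc(OCc2ccc(-c3noc(-c4ccccc4F)n3)cc2)c1`: > 100000 nM, likewise a limit of the assay
compound 3 `COc1ccc(C(=O)NO)cc1OCc1noc(-c2ccccc2)n1`: 36500 nM

In an assay on isolated protein for inhibition of sphingomyelin phosphodiesterase (Homo sapiens), read by fluorescence, with a stated time of 30 min (a lower number here means a stronger inhibitor, a higher number a weaker inhibitor), compound 1 sits at a limit. Compound 2, which differs from compound 1 by fluoro in place of hydrogen on an aromatic carbon, sits at the same limit in this assay. The step that the two limits leave unreadable from compound 1 to compound 2 therefore has no readable size because of the limit of > 100000 nM in this assay, at which 2 of the 3 values shown sit. Compound 3 is the only one of the three to give a number in this assay; the difference between its core and that of compound 1 is not broken down here. Compound 4 `COc1ccc(C(=O)NO)cc1OCc1noc(-c2ccccc2F)n1` carries the same change as the pair above, (fluoro in place of hydrogen on an aromatic carbon). For compound 4 the expected step is a 1.2-fold lower number from compound 3 to compound 4 (0.09 log units; within the scatter), as a step that the two limits leave unreadable from compound 1 to compound 2 offers no size to lean on. Compound 4 is estimated at 30000 nM, between 10000 nM and 100000 nM.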

Compound 4, half-maximal inhibitory concentration: 21600 nM
The estimate for compound 4 lay 1.4-fold (0.14 log units) above the measured number; measured number inside the range.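

In this assay the change from phenyl to 2-fluorophenyl gives a 1.7-fold lower number from compound 3 to compound 4 (0.23 log units; within the scatter) on the core of compound 3, so on this core the step does not stand clear of the scatter of repeated measurements. This is a single readable step and shows no trend for fluoro in place of hydrogen. Whether the step carries over from one core to another stays unshown, because the matching step on the core of compound 1 cannot be read, with compound 1 and compound 2 both at a limit of the assay rather than a number: the limit of > 100000 nM in this assay, at which 2 of the 4 values shown sit.

The compounds shown leave open whether a chloro group, an amine or a carboxylic acid in place of that hydrogen would move the number on the core of compound 3 beyond the scatter. They also leave open what any such group would do on the core of compound 1.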